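Sulfonamide chain shortening in a weak antiproliferative series

A few compounds are considered here, and "the series" means these few. Any claim that something is new, unique, unknown or untested is made for them only; others in the source may bear on it.

Three compounds on a shared core have been run in a functional assay on NCI-H1975 cells (Homo sapiens) for antiproliferative activity, read by CCK-8 assay, with a stated time of 72 h; on this read-out lower numbers stand for stronger inhibition of growth and higher numbers for weaker inhibition of growth. Compound 1 `CCC1C(=O)N(C)c2cnc(-n3ccc4cc(C(N)=O)ccc43)nc2N1c1ccn(C)n1` is reported as "not active" (no number reported) in this assay, with no number attached. Compound 2 `CCC1C(=O)N(C)c2cnc(Nc3ccc(S(=O)(=O)NCC(C)C)cc3)nc2N1c1ccn(C)n1` gives 15000 nM in this assay, the highest of the two numbers recorded. Compound 3 `CCCCNC(=O)c1ccc2c(ccn2-c2ncc3c(n2)N(c2ccn(C)n2)C(CC)C(=O)N3C)c1` gives 12000 nM in this assay; the gap between compound 3 and compound 2 lies within the scatter, so no order can be read from the pair.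

Compound 4 `CCC1C(=O)N(C)c2cnc(Nc3ccc(S(=O)(=O)NC)cc3)nc2N1c1ccn(C)n1` has not been measured. It differs from compound 2 in one place: hydrogen in place of isopropyl on a saturated chain carbon bound to a sulfonamide nitrogen. Among the measured compounds shown here, no step between measured compounds covers this change, so the expectation rests on compound 2 alone. Given that compound 2 gives 15000 nM in this assay, the step is expected to be small, none beyond the scatter in either direction, with the weak range of the series in mind. Compound 4 is estimated at 20000 nM in this assay, between 7000 nM and 55000 nM, which corresponds to an expected step of a 1.3-fold higher number from compound 2 to compound 4 (0.12 log units; within the scatter).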

Compound 4, concentration for 50% growth inhibition: 18800 nM
Estimate against measurement, compound 4: 1.1-fold (0.03 log units) above; the range from low to high includes it.
By their numbers in this assay, from the lowest: compounds 3, 2 and 4 (each within the scatter of the next).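

In this assay, among the compounds shown here, going from isobutylsulfamoyl to methylsulfamoyl gives a 1.3-fold higher number from compound 2 to compound 4 (0.10 log units; within the scatter), the first step that isolates a single place. On this pair, the chain on the sulfonamide nitrogen can be cut from isobutyl to methyl without the read-out leaving the scatter, so chain length over this span does not separate the two compounds. Nothing available bears on why the pair reads alike.

As far as these compounds go, whether a chain longer than isobutyl, or one ending in an amine or a carboxylic acid, would move the number out of the weak range remains open. A single step also cannot show whether this sulfonamide nitrogen tolerates change generally or whether the flat result is limited to the isobutyl and methyl pair.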